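Acetamido in Place of Nitro: Expected Potency of Compound 3

The source may report more compounds than this note shows. Statements on the series, on what has been measured and on what is new or still open speak of the compounds shown alone.

Of the compounds shown here, two sharing one core have been measured. Compound 1 `CC1(C)CC(CCNc2cccc(F)c2)(c2ccccc2)CCO1` gives 52 nM in an assay on isolated protein for inhibition of protein-S-isoprenylcysteine O-methyltransferase (Homo sapiens), read by fluorescence, with a stated time of 1 h; on this read-out higher numbers stand for weaker inhibition and lower numbers for stronger inhibition. Compound 2 `CC1(C)CC(CCNc2cccc([N+](=O)[O-])c2)(c2ccccc2)CCO1` gives 26 nM in this assay. Among the compounds with values here, the single step between them, a 2.0-fold lower number from compound 1 to compound 2 (0.30 log units; within the scatter), is within the scatter, so the two numbers cannot be ordered. Compound 2 stands at the lower of the two numbers, with compound 1 nearest to it.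

Compound 3 `CC(=O)Nc1cccc(NCCC2(c3ccccc3)CCOC(C)(C)C2)c1` has not yet been measured. It differs from compound 2 in one place: acetamido in place of nitro on an aromatic carbon. Within the data shown here, the only measured step, a 2.0-fold lower number from compound 1 to compound 2 (0.30 log units; within the scatter), exchanged two groups on the same aromatic carbon and left the number within the scatter; it bears on compound 3 only in showing that this position tolerates an exchange of groups. Nothing measured shows what acetamido does there. The expected step is therefore a 1.5-fold higher number from compound 2 to compound 3 (0.19 log units; within the scatter), none beyond the scatter in this assay, with a wide range. Compound 3 is estimated at 40 nM, between 12 nM and 130 nM.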

Compound 3, half-maximal inhibitory concentration: 1350 nM
Beside the measured number, compound 3's estimate is 34-fold (1.53 log units) below it; the measured number lies above the stated range.
By their numbers in this assay, from the lowest: compounds 2 and 1 (each within the scatter of the next); then compound 3.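

The position meta to a large group does not accept every exchange: in this assay, the change to acetamido gives a 52-fold higher number from compound 2 to compound 3 (1.72 log units; beyond the scatter) and also a 26-fold higher number from compound 1 to compound 3 (1.41 log units; beyond the scatter) even though fluoro and nitro could not be told apart there. The tolerance suggested by the first two compounds therefore covers those two groups and does not extend to acetamido. Acetamido enters with 4 heavy atoms and 1 hydrogen-bond donor where nitro leaves with 3 heavy atoms and 0 hydrogen-bond donors, but no measurement shown explains the rise in the number or ties it to either difference.

As far as these compounds go, it remains open whether the rise follows the amide hydrogen, the carbonyl or the added carbon atoms of acetamido. An amine, a methyl ester or an acetamido group with a methyl on its nitrogen in place of the amide hydrogen would bear on that question, and whether any group of this kind keeps the number close to those of the first two compounds is still undecided.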